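The source may hold more compounds than are shown below. What is called first, only, known or untested is meant among the compounds shown, and "the series" means these compounds.

Compound 1 `N#Cc1c(NC(=O)CCc2ccccc2)sc2c1CCCC2` carries an unsubstituted phenyl on the propanamide chain attached to the shared core; in a functional assay on RKE cells for antagonist activity at Vasoactive intestinal polypeptide receptor 1 (Rattus norvegicus), read by HTRF and cAMP accumulation, with stated times of 10 min and 30 min (on this read-out higher numbers stand for weaker inhibition and lower numbers for stronger inhibition), compound 1 gives 290 nM. Compound 2 `Cc1cccc(CCC(=O)Nc2sc3c(c2C#N)CCCC3)c1` gives 750 nM, and compound 3 `COc1ccc(CCC(=O)Nc2sc3c(c2C#N)CCCC3)cc1` gives 410 nM. Among these three numbers compound 3 sits second highest; its values against compound 1 and against compound 2 both fall within the scatter, so no order among the three is secure, though the step from compound 1 to compound 2 on its own was a 2.6-fold higher number from compound 1 to compound 2 (0.41 log units; beyond the scatter).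

Compound 4 `N#Cc1c(NC(=O)CCc2ccc(Cl)cc2)sc2c1CCCC2` differs from compound 3 by chloro in place of methoxy on an aromatic carbon. Going by the values given here, no measured step swaps these two groups directly. The closest comparisons are a 1.4-fold higher number from compound 1 to compound 3 (0.15 log units; within the scatter) and a 1.8-fold lower number from compound 2 to compound 3 (0.26 log units; within the scatter), both small, which suggests that a change at this position of the phenyl ring moves this assay little. The expected step is therefore a 1.2-fold lower number from compound 3 to compound 4 (0.07 log units; within the scatter), that is, none beyond the scatter. Compound 4 is estimated at 350 nM, with a range from 150 nM to 800 nM.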

Compound 4, half-maximal inhibitory concentration: 1200 nM
Compound 4: the middle estimate sits 3.4-fold (0.54 log units) below what was measured; measured number above the stated range.
By their numbers in this assay, from the lowest: compounds 1, 3, 2 and 4 (each within the scatter of the next, the first and the last beyond it).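

The position para to a large group proves sensitive to which group sits there: in this assay the exchange of methoxy for chloro gives a 2.9-fold higher number from compound 3 to compound 4 (0.47 log units; beyond the scatter) and chloro in place of hydrogen gives a 4.1-fold higher number from compound 1 to compound 4 (0.62 log units; beyond the scatter) whereas methoxy in place of hydrogen gave only a 1.4-fold higher number from compound 1 to compound 3 (0.15 log units; within the scatter). The earlier small steps therefore did not show that this place tolerates every group, although a 1.6-fold higher number from compound 2 to compound 4 (0.20 log units; within the scatter) leaves no secure order between the 3-methylphenyl and 4-chlorophenyl compounds. No measurement shown here accounts for the different readings of chloro and methoxy.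

The compounds shown leave open how fluoro, hydroxy or an amine would read at this same place on the phenyl ring. They also leave open whether the gap between chloro and methoxy would hold on a longer chain.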